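Compound 3 and the furan-3-yl swap

This account rests on a few compounds, and the source may have more. Where it says the series, first, only, none or still open, it means among the compounds named here.

Doses measured in a functional assay on the whole organism with Mus musculus as the target (a higher number here means that more compound is needed for the effect, a lower number that less compound is needed), so far:
compound 1 `CNC(=O)CNCc1ccc(OCc2cccc(Cl)c2)cc1` – 30.5 mg/kg
compound 2 `C[C@@H](NCc1ccc(COc2ccccc2)cc1)C(N)=O` – 40.3 mg/kg
compound 3 `C[C@@H](NCc1ccc(OCc2ccc(F)cc2)cc1)C(N)=O` – 132 mg/kg

Compound 3 (132 mg/kg) has the highest number of the three, and its gaps to the other two lie beyond the scatter. The next compound to be tested, compound 4 `C[C@@H](NCc1ccc(OCc2ccoc2)cc1)C(N)=O`, carries furan-3-yl in place of 4-fluorophenyl on a saturated chain carbon bound to an oxygen on an aromatic ring. Within the data shown here, no two measured compounds differ in one place alone, so the data offer no direct precedent for this change. Among the measured compounds shown here, the only guide is the spread of values: compound 2 (40.3 mg/kg) and compound 1 (30.5 mg/kg) both need less compound than compound 3 does. A moderate step towards a lower number is therefore expected, though with little certainty. The expected change is a 2.2-fold lower number from compound 3 to compound 4 (0.34 log units; beyond the scatter) in this assay. The estimate for compound 4 is 60 mg/kg (estimated range 25 mg/kg to 140 mg/kg).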

Compound 4, dose for half-maximal effect: 152 mg/kg
Compound 4: the middle estimate sits 2.5-fold (0.40 log units) below what was measured; measured number above the stated range.
By their numbers in this assay, from the lowest: compounds 1 and 2 (each within the scatter of the next); then compounds 3 and 4 (each within the scatter of the next).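

In this assay, furan-3-yl in place of 4-fluorophenyl on a saturated chain carbon bound to an oxygen on an aromatic ring gives a 1.2-fold higher number from compound 3 to compound 4 (0.06 log units; within the scatter) and so leaves the two compounds level. Among these compounds, this is the first comparison that differs in one place alone, and it shows that at this position a five-membered aromatic ring with one hetero atom and a six-membered aromatic ring of carbon only give the same result within the scatter. Nothing at hand explains this outcome.

From the compounds shown here alone, it stays open whether groups of another kind at this position, such as an amine, a carboxylic acid or a longer chain in place of the ring, would also leave the dose unchanged. Going by these compounds, with a single step at one position, it also remains unknown whether this exchange would give the same result on the core of compound 1.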